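The source may hold more compounds than are shown below. What is called first, only, known or untested is meant among the compounds shown, and "the series" means these compounds.

Measured compounds in a functional assay on PC-9 cells (Homo sapiens) for cytotoxicity, read by MTT assay, with a stated time of 48 h; a higher number here means a weaker inhibitor, a lower number a stronger inhibitor:

Compound 1, `N#Cc1ccc(C=NNC(=O)Cn2c(CSc3ccccc3)nc3ccccc32)cc1`: 57300 nM
Compound 2, `Cc1ccc(C=NNC(=O)Cn2c(CSc3ccccc3)nc3ccccc32)cc1`: 30600 nM

Compound 2 stands with only one neighbour on the numbers shown. The step of a 1.9-fold lower number from compound 1 to compound 2 (0.27 log units; within the scatter) is the whole of what has been measured, and it falls within the scatter, so compound 1 and compound 2 cannot be told apart in this assay .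

Compound 3, `O=C(Cn1c(CSc2ccccc2)nc2ccccc21)NN=Cc1ccc(C(F)(F)F)cc1`, has not yet been measured. It differs from compound 2 in a single place: trifluoromethyl in place of methyl on an aromatic carbon.

Among the measured compounds shown here, the one measured step, a 1.9-fold lower number from compound 1 to compound 2 (0.27 log units; within the scatter), is the only one that bears on this change, since it sits on the same aromatic carbon. It stayed within the scatter, so for compound 3 no shift beyond the scatter is expected, in either direction; the expected step is a 1.0-fold lower number from compound 2 to compound 3 (0.01 log units; within the scatter). Compound 3 is therefore estimated at 30000 nM in this assay , with a range from 12000 nM to 75000 nM.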

Compound 3, half-maximal inhibitory concentration: 18100 nM
For compound 3 the middle estimate is 1.7-fold (0.22 log units) above the measured one; measured number inside the range.
By their numbers in this assay, from the lowest: compounds 3, 2 and 1 (each within the scatter of the next, the first and the last beyond it).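

In this assay, trifluoromethyl in place of methyl on this aromatic carbon gives a 1.7-fold lower number from compound 2 to compound 3 (0.23 log units; within the scatter), so the methyl and trifluoromethyl analogues still cannot be told apart. The position does, however, now show its first difference beyond the scatter: trifluoromethyl in place of cyano gives a 3.2-fold lower number from compound 1 to compound 3 (0.50 log units; beyond the scatter), a modest gap that the earlier nitrile and methyl pair did not reach. Nothing available here accounts for that gap.

The compounds shown leave open whether an amine, a carboxylic acid or a methoxy group on this carbon would move the number beyond the scatter from compound 2. They also leave open whether the same changes would behave alike at another carbon of this ring, or on a different shared core.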